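Swapping a benzyl ring on a triazole amide

This account rests on a few compounds, and the source may have more. Where it says the series, first, only, none or still open, it means among the compounds named here.

Measured compounds:
compound 1 `O=C(NCc1cn(Cc2ccc(F)cc2)nn1)c1cn(-c2ccccc2)nc1-c1ccc(F)cc1` — 14300 nM
compound 2 `O=C(NCc1cn(Cc2ccc(F)cc2)nn1)c1cn(-c2ccccc2)nc1-c1ccc(Cl)cc1` — 1990 nM

Both compounds were tested in a functional assay on MIA PaCa-2 cells (Homo sapiens) for antiproliferative activity, read by sulforhodamine B assay, with a stated time of 48 h; on this read-out lower numbers stand for stronger inhibition of growth and higher numbers for weaker inhibition of growth. Within the data shown here, of the two numbers, compound 2 holds the lowest, with compound 1 the nearest, and the only measured step is a 7.2-fold lower number from compound 1 to compound 2 (0.86 log units; beyond the scatter), obtained by chloro in place of fluoro on an aromatic carbon.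

Compound 3 `COc1cc(Cn2cc(CNC(=O)c3cn(-c4ccccc4)nc3-c3ccc(Cl)cc3)nn2)cc(OC)c1OC` is not yet measured. Compared with compound 2, it carries 3,4,5-trimethoxyphenyl in place of 4-fluorophenyl on a saturated chain carbon bound to an aromatic nitrogen. Among the measured compounds shown here, this change sits on a different part of the molecule than the one measured step, which concerns the halogen on the aromatic ring attached to the shared core. For the measured compounds named here, the single measured step therefore gives no direct guide to how the benzyl ring swap will turn out, and no other pair among the measured compounds speaks to it.

With only the behaviour of compound 2 as an anchor, compound 3 is expected to land close to it, with a step of a 1.3-fold lower number from compound 2 to compound 3 (0.12 log units; within the scatter) in this assay. The estimate for compound 3 is 1500 nM, within a range from 300 nM to 8000 nM.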

Compound 3, concentration for 50% growth inhibition: 3500 nM
Compound 3: the middle estimate sits 2.3-fold (0.37 log units) below what was measured, within the range that was stated.
By their numbers in this assay, from the lowest: compounds 2 and 3 (each within the scatter of the next); then compound 1.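

Among these compounds, the a 1.8-fold higher number from compound 2 to compound 3 (0.25 log units; within the scatter) in this assay gives the first reading at this position: 3,4,5-trimethoxyphenyl, with 12 heavy atoms and 3 hydrogen-bond acceptors, and 4-fluorophenyl, with 7 heavy atoms and no hydrogen-bond acceptors, cannot be told apart on this read-out. In these three compounds, the halogen step, a 7.2-fold lower number from compound 1 to compound 2 (0.86 log units; beyond the scatter), lies beyond the scatter, whereas the benzyl ring swap stays within it, even though the swap replaces a much bigger piece of the molecule. No measured evidence is available to explain why these two different groups read so alike.

One swap cannot show how far this tolerance extends, so a benzyl ring carrying an amine or a carboxylic acid, or a plain methyl group in place of the ring, might behave quite differently. On these data alone, it also remains open whether exchanging chloro for fluoro on the aromatic carbon would give a step of the same size in a compound carrying the 3,4,5-trimethoxyphenyl group.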